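The source may hold more compounds than are shown below. What is called first, only, known or untested is meant among the compounds shown, and "the series" means these compounds.

The measured compounds, each tested in an ADME assay on HEK293 cells (Homo sapiens) for inhibition, read by CellTiter-Glo, with a stated time of 96 h, tested at 100 uM; on this read-out higher numbers stand for more inhibition at the one concentration tested (going by the name of the read-out) and lower numbers for less inhibition:

compound 1 `CCOC(=O)/C=C/NC(=O)[C@H](O)C(C)(C)CO`, which gives -5%;
compound 2 `CCOC(=O)/C=C\NC(=O)[C@H](O)C(C)(C)CO`, which gives -6%;
compound 3 `CCOC(=O)/C=C\NC(=O)[C@@H](O)C(C)(C)CO`, which gives -6%.

All three sit together: a number 1 percentage points lower from compound 1 to compound 2 (within the scatter), a number 1 percentage points lower from compound 1 to compound 3 (within the scatter) and no change at the digits printed from compound 2 to compound 3 (within the scatter). None of these three steps alters the atoms or bonds; they rest on (the fact that compounds 1 and 2 differ only in the configuration as drawn), the fact that compounds 1 and 3 differ only in the configuration as drawn and (the fact that compounds 2 and 3 differ only in the configuration as drawn), so the series tells only that redrawing the double bond or the saturated chain stereocentre leaves the read-out where it was.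

The unmeasured compound 4 `COC(=O)/C=C/NC(=O)[C@H](O)C(C)(C)CO` is reached from compound 1 by a change of a different kind: hydrogen in place of methyl on a saturated chain carbon bound to an oxygen next to a carbonyl group. Going by the values given here, no measured step touches this ethoxycarbonyl group, so nothing speaks directly for or against a movement here. What the series does show is that three closely related compounds all sit near zero in this assay, and ethyl to methyl on an ester is a small change in size.

Compound 4 is therefore expected to give about -5%, with a plausible span from -15% to 6%, which means an expected step of no change at the digits printed from compound 1 to compound 4 (within the scatter), not beyond the scatter.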

Compound 4, a percentage reported as inhibition, at one concentration (the size of the read-out at that concentration, not a potency): 0%
Estimate against measurement, compound 4: 5 percentage points below; measured number inside the range.
By their numbers in this assay, from the lowest: compounds 2, 3, 1 and 4 (each within the scatter of the next).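

Replacing the ethoxycarbonyl group of compound 1 with methoxycarbonyl gives, in this assay, a number 5 percentage points higher from compound 1 to compound 4 (within the scatter), so this step too stays inside the usual spread of repeated measurements. Going by these compounds alone, the earlier compounds differed only in configuration as drawn, whereas this is the first step to alter the atoms themselves, and it shows that losing a methyl from the saturated chain carbon bound to an oxygen next to a carbonyl group does not carry the read-out beyond the scatter, leaving all four compounds together. What this says about the ester end reaches no further than this ethyl to methyl change, and nothing available bears on why the read-out behaves as it does at this place.

The compounds shown leave open whether a bigger change at this end would read the same, for instance a carboxylic acid in place of the ester, a primary amide, or a longer chain such as propyl or benzyl on the oxygen. They also leave open whether changes elsewhere on the shared core, such as an amine in place of the free hydroxyl group, would move the number in this assay beyond the scatter.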